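The source may report more compounds than this note shows. Statements on the series, on what has been measured and on what is new or still open speak of the compounds shown alone.

Measured so far in a functional assay on MDA-MB-231 cells (Homo sapiens) for antiproliferative activity, read by MTT assay, with a stated time of 48 h; on this read-out lower numbers stand for stronger inhibition and higher numbers for weaker inhibition:
Compound 1 `C=CS(=O)(=O)N1CCN(c2ncnc3sc(-c4ccc(OC)cc4)cc23)CC1`: 29900 nM
Compound 2 `C=CS(=O)(=O)N1CCN(c2ncnc3sc(-c4ccc(C#N)cc4)cc23)CC1`: 8050 nM
Compound 3 `C=CS(=O)(=O)N1CCN(c2ncnc3sc(-c4cccc5ccccc45)cc23)CC1`: 23700 nM

Compound 3 cannot be separated from compound 1, as shown by a 1.3-fold lower number from compound 1 to compound 3 (0.10 log units; within the scatter). It does stand apart from compound 2, as shown by a 2.9-fold higher number from compound 2 to compound 3 (0.47 log units; beyond the scatter).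

The next compound, compound 4 `C=CS(=O)(=O)N1CCN(c2ncnc3sc(-c4ccnc(Cl)c4)cc23)CC1`, keeps the shared core and has 2-chloropyridin-4-yl in place of naphthalen-1-yl on an aromatic carbon, next to the ring sulfur: 2-chloropyridin-4-yl in place of naphthalen-1-yl on an aromatic carbon.

The measured steps that bear on this change are those at the same place. Only the cyano compound departs from the other two, and modestly, with a 3.7-fold lower number from compound 1 to compound 2 (0.57 log units; beyond the scatter). The entering group has a chlorine and a hetero atom in its aromatic ring, and neither occurs in the measured compounds, so the data give no direct reading of either feature. Across the three measured compounds, the numbers stay within a narrow band. A modest step toward a lower number in this assay is therefore expected, no larger than a 2.9-fold higher number from compound 2 to compound 3 (0.47 log units; beyond the scatter) and possibly not beyond the scatter. The expected step is a 1.7-fold lower number from compound 3 to compound 4 (0.23 log units; within the scatter). Compound 4 is estimated at 14000 nM, with an expected range of 5000 nM to 35000 nM.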

Compound 4, half-maximal inhibitory concentration: 27700 nM
The estimate for compound 4 lay 2.0-fold (0.30 log units) below the measured number, within the range that was stated.
By their numbers in this assay, from the lowest: compound 2; then compounds 3, 4 and 1 (each within the scatter of the next).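

In this assay, 2-chloropyridin-4-yl on this aromatic carbon next to the ring sulfur cannot be separated from naphthalen-1-yl, with a 1.2-fold higher number from compound 3 to compound 4 (0.07 log units; within the scatter), or from 4-methoxyphenyl, with a 1.1-fold lower number from compound 1 to compound 4 (0.03 log units; within the scatter), so one six-membered aromatic ring with a hetero atom and a chlorine reads here like two six-membered aromatic rings of carbon only. The step with a 3.4-fold higher number from compound 2 to compound 4 (0.54 log units; beyond the scatter) leaves 4-cyanophenyl as the one group among the four shown at this place whose steps to all the others lie beyond the scatter, which makes compound 2 the only compound that stands apart in this series. No measured evidence bears on why three such different groups read alike here.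

Open, on these data alone, is whether the chlorine and the ring nitrogen of 2-chloropyridin-4-yl would each read the same on their own, and whether a nitrile carried on that pyridine ring would match compound 2 rather than compound 4. Also open, as far as these compounds go, is how an amine or a carboxylic acid on the phenyl ring in place of the nitrile would read at this place.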